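From Ester to Ketone on a Shared Core

The source may report more compounds than this note shows. Statements on the series, on what has been measured and on what is new or still open speak of the compounds shown alone.

Measured compounds:
compound 1 `CCOC(=O)c1ccc2oc(N3CCN(C)CC3)nc2c1` — < 4
compound 2 `COc1cc(C)cc2nc(N3CCN(C)CC3)oc12` — 6.13
compound 3 `CN1CCN(c2nc3cccc(Cl)c3o2)CC1` — 5.5

In a functional assay on ileum (strain Hartley) for agonist activity at 5-hydroxytryptamine receptor 3A (Cavia porcellus) (on this read-out higher numbers stand for higher potency (the scale is a negative logarithm) and lower numbers for lower potency), compound 1 returns only a limit, < 4, not a number. That limit is the point at which (the limit of < 4 in this assay, at which 1 of the 3 values shown sits). Compound 2 gives 6.13 in this assay. Compound 3 gives 5.5 in this assay. Compound 1 therefore stands at the bottom of the three, and only as a limit.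

Compound 4 `CC(=O)c1ccc2oc(N3CCN(C)CC3)nc2c1` differs from compound 1 by methyl in place of ethoxy on a carbonyl carbon. Within the data shown here, no measured pair shows this particular change, so its size can only be expected, not read off. The carbonyl on the ring is kept in compound 4, and compound 1, which carries the same carbonyl, sits at the limit < 4. The step from compound 1 to compound 4 is expected to be a number at least 0.30 log units higher from compound 1 to compound 4 (that floor lies within the scatter), a small rise that may not clear the usual scatter. Compound 4 is thus estimated at 4.3, with a range from 3.5 to 5.2, and a fair chance that it too is reported only as a limit.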

Compound 4, negative logarithm of the half-maximal effective concentration: < 4
Compound 4 gave a limit, no number (the forecaster's own chance of this, stated with the estimate: 50%); middle value at least 0.30 log units from the limit.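

No step can be read from compound 1 to compound 4, since in this assay each of the two returns only a limit and no number: the limit of < 4 in this assay, at which 2 of the 4 values shown sit.

The compounds shown leave open the size, and even the direction, of any effect on potency of methyl in place of ethoxy on a carbonyl carbon.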